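Furan to bromothiophene on the amine side chain

This account rests on a few compounds, and the source may have more. Where it says the series, first, only, none or still open, it means among the compounds named here.

Of the compounds shown here, three have been measured in an ADME assay on MDCK cells (Canis lupus familiaris) for cytotoxicity, read by microscopy, with a stated time of 48 h; on this read-out lower numbers stand for higher toxicity in this test and higher numbers for lower toxicity in this test. Compound 1 `C=Cc1ccsc1CN[C@@H]1C[C@H]2C[C@@H]([C@H]1C)C2(C)C` gives 50000 nM. Within the data shown here, compound 2 `CCCCc1ccsc1CN[C@@H]1C[C@H]2C[C@@H]([C@H]1C)C2(C)C` gives 25000 nM, and the step of a 2.0-fold lower number from compound 1 to compound 2 (0.30 log units; within the scatter) is the only single-point comparison among the measured compounds. For compound 3 `C[C@H]1[C@H](NCc2ccoc2)C[C@H]2C[C@@H]1C2(C)C` the read-out in this assay is a limit, > 100000 nM, so compound 3 stands at the limit of > 100000 nM in this assay, at which 1 of the 3 values shown sits, and not at a number. Compound 4 `C[C@H]1[C@H](NCc2sccc2Br)C[C@H]2C[C@@H]1C2(C)C` differs from compound 3 by 3-bromothiophen-2-yl in place of furan-3-yl on a saturated chain carbon bound to an amine nitrogen. Among the measured compounds shown here, no measured step covers this exchange of one five-membered aromatic ring for another; the single known step, butyl in place of vinyl on an aromatic carbon, lies within the scatter and bears on it only loosely. The two thiophene-bearing compounds, compound 1 and compound 2, sit at numbers rather than at a limit, which is the one pointer available. Compound 4 is expected to move from the limit toward those numbers, a step of an at least 2.0-fold lower number from compound 3 to compound 4 (0.30 log units; that floor lies within the scatter), with a fair chance that it also returns only a limit. The estimate for compound 4 is 50000 nM, between 20000 nM and 100000 nM.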

Compound 4, minimum cytotoxic concentration: 50000 nM
Compound 4: middle estimate and measured number agree at the digits printed; low and high end bracket the measured number.
By their numbers in this assay, from the lowest: compounds 2, 1 and 4 (each within the scatter of the next). At a limit, above all of these: compound 3.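

In this assay the change at this position gives an at least 2.0-fold lower number from compound 3 to compound 4 (0.30 log units; that floor lies within the scatter), with 3-bromothiophen-2-yl in place of furan-3-yl on a saturated chain carbon bound to an amine nitrogen. Compound 3 stays a limit and not a number: the limit of > 100000 nM in this assay, at which 1 of the 4 values shown sits. Among the thiophene-bearing compounds, bromo, vinyl and butyl on the aromatic carbon are not told apart, with no change at the digits printed from compound 1 to compound 4 (within the scatter) and a 2.0-fold higher number from compound 2 to compound 4 (0.30 log units; within the scatter).

Still open, as far as these compounds go, is how far the step from furan-3-yl really reaches, since only a floor is available, and whether a furan ring carrying bromo would read as compound 4 does. Also open, from the compounds shown here alone, is whether a carboxylic acid or an amine on that aromatic carbon would stay within the scatter of compound 4.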